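The source may report more compounds than this note shows. Statements on the series, on what has been measured and on what is new or still open speak of the compounds shown alone.

In a functional assay on HeLa cells (Homo sapiens) for antiproliferative activity, read by resazurin assay (a lower number here means a stronger inhibitor, a higher number a weaker inhibitor), compound 1 `CCSC(=S)SCC(=O)c1ccc(Cl)c(Cl)c1` gives 7940 nM, compound 2 `CCSC(=S)SCC(=O)c1ccc(OC)cc1OC` gives 12600 nM, and compound 3 `O=C(CSC(=S)Sc1ccccc1)c1ccc(Cl)c(Cl)c1` gives 20000 nM. Compound 3 thus carries the highest of the three numbers; its gap to compound 2 lies within the scatter, while compound 1 sits clearly lower, as the step of a 2.5-fold higher number from compound 1 to compound 3 (0.40 log units; beyond the scatter) shows.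

Compound 4 `CSC(=S)SCC(=O)c1ccc(Cl)c(Cl)c1` differs from compound 3 in one place: methyl in place of phenyl on a sulfur. For the measured compounds named here, the only measured step that bears on this change is the one from compound 1 to compound 3, where phenyl in place of ethyl on a sulfur raised the number by a 2.5-fold higher number from compound 1 to compound 3 (0.40 log units; beyond the scatter). The move to compound 4 runs the other way, from phenyl back to a short alkyl on that sulfur, so a lower number of roughly that size is expected, although ethyl and methyl are not the same group and no direct comparison between them exists here. Compound 4 is therefore estimated at 8500 nM in this assay, with a range of 3500 nM to 22000 nM, meaning an expected step of a 2.4-fold lower number from compound 3 to compound 4 (0.37 log units; beyond the scatter).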

Compound 4, half-maximal inhibitory concentration: 6310 nM
Compound 4: middle estimate off by 1.3-fold (0.13 log units), on the high side, within the range that was stated.
By their numbers in this assay, from the lowest: compounds 4, 1, 2 and 3 (each within the scatter of the next, the first and the last beyond it).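

The new step confirms the earlier reading from a second direction: on the sulfur whose other neighbour is the thiocarbonyl carbon, the change from phenylsulfanyl to methylsulfanyl gives a 3.2-fold lower number from compound 3 to compound 4 (0.50 log units; beyond the scatter) in this assay, so compound 3 stands apart from both short alkyl compounds. Shortening the alkyl group itself makes no difference that can be read, since a 1.3-fold lower number from compound 1 to compound 4 (0.10 log units; within the scatter) leaves ethyl and methyl on this sulfur indistinguishable. No available evidence accounts for the gap between phenyl and these short alkyl groups.

The compounds shown do not tell whether a longer chain, a benzyl group or a chain ending in an amine or a carboxylic acid on this sulfur would behave like the short alkyl groups or like phenyl. They also leave open whether the same change would give a similar step on the core of compound 2.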